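Hydroxyphenyl change from compound 3 to compound 4

A few compounds are considered here, and "the series" means these few. Any claim that something is new, unique, unknown or untested is made for them only; others in the source may bear on it.

In a functional assay on SGC-7901 cells (Homo sapiens) for inhibition, read by MTT assay, with a stated time of 24 h (a higher number here means a weaker inhibitor, a lower number a stronger inhibitor), compound 1 (`CC1(C)[C@H]2CC[C@]1(C)N(Cc1cn(-c3ccc(F)cc3)nn1)C(=O)C2`) gives 500 nM, compound 2 (`CC1(C)[C@H]2CC[C@]1(C)N(Cc1cn(-c3ccc(Br)cc3)nn1)C(=O)C2`) gives 450 nM and compound 3 (`CC1(C)[C@H]2CC[C@]1(C)N(Cc1cn(-c3ccccc3O)nn1)C(=O)C2`) gives 410 nM. Compound 3 stands level with the other two: a 1.2-fold lower number from compound 1 to compound 3 (0.09 log units; within the scatter) and a 1.1-fold lower number from compound 2 to compound 3 (0.04 log units; within the scatter). The remaining step, a 1.1-fold lower number from compound 1 to compound 2 (0.05 log units; within the scatter), is equally small. Compound 4 (`CC1(C)[C@H]2CC[C@]1(C)N(Cc1cn(-c3cccc(O)c3)nn1)C(=O)C2`) differs from compound 3 as follows: 3-hydroxyphenyl in place of 2-hydroxyphenyl on an aromatic nitrogen. It carries 3-hydroxyphenyl in place of 2-hydroxyphenyl on an aromatic nitrogen. All three measured steps change the same aryl group, but none relocates a hydroxyl, so they bear on this change only indirectly. The expected size in this assay is a 1.0-fold higher number from compound 3 to compound 4 (0.02 log units; within the scatter), with no direction expected beyond the scatter. The estimate for compound 4 is 430 nM, with an expected range of 220 nM to 800 nM.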

Compound 4, half-maximal inhibitory concentration: 270 nM
The estimate for compound 4 lay 1.6-fold (0.20 log units) above the measured number; low and high end bracket the measured number.
By their numbers in this assay, from the lowest: compounds 4, 3, 2 and 1 (each within the scatter of the next).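

In this assay, among the compounds shown here, moving the hydroxyl, which no earlier step did, gives a 1.5-fold lower number from compound 3 to compound 4 (0.18 log units; within the scatter) and so stays within the scatter. Against the halogen-bearing aryl groups, 3-hydroxyphenyl gives a 1.7-fold lower number from compound 2 to compound 4 (0.22 log units; within the scatter) and a 1.9-fold lower number from compound 1 to compound 4 (0.27 log units; within the scatter) and so stands level with 4-bromophenyl and 4-fluorophenyl alike. Nothing available gives a reason for these steps. Open, on these data alone, is whether 4-hydroxyphenyl, or an aryl group carrying an amine or a carboxylic acid, would move the number beyond the scatter.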